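This account rests on a few compounds, and the source may have more. Where it says the series, first, only, none or still open, it means among the compounds named here.

Notes on the series. The shared core is carried by compound 1 `COc1cc(-c2nnc3n2NC(c2ccco2)C(C(=O)c2ccc(C)cc2)S3)cc(OC)c1OC`, compound 2 `COc1cc(-c2nnc3n2NC(c2ccco2)C(C(=O)c2ccc(C(F)(F)F)cc2)S3)cc(OC)c1OC` and compound 3 `COc1cc(-c2nnc3n2NC(c2ccco2)C(C(=O)c2ccc(-c4ccccc4)cc2)S3)cc(OC)c1OC`. In a functional assay on PC-3 cells (Homo sapiens) for cytotoxicity, read by MTT assay, with a stated time of 48 h (a higher number here means a weaker inhibitor, a lower number a stronger inhibitor), compound 1 gives 7500 nM, compound 2 gives 77500 nM and compound 3 gives 45900 nM. Compound 3 thus stands second highest of the three numbers; its nearest neighbour is compound 2, and the two lie within the scatter of each other, while compound 1 is furthest off, with a 6.1-fold higher number from compound 1 to compound 3 (0.79 log units; beyond the scatter). The remaining step, a 10-fold higher number from compound 1 to compound 2 (1.01 log units; beyond the scatter), also runs upward from compound 1.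

Compound 4 `COc1cc(-c2nnc3n2NC(c2ccco2)C(C(=O)c2ccccc2C)S3)cc(OC)c1OC` is the next candidate. 2-methylphenyl in place of 4-phenylphenyl on a carbonyl carbon The step that bears on it is a 6.1-fold higher number from compound 1 to compound 3 (0.79 log units; beyond the scatter): compound 4 removes the phenyl that compound 3 gained, so the reverse of that change is the nearest guide. The step of a 1.7-fold lower number from compound 2 to compound 3 (0.23 log units; within the scatter) says little here. Compound 4 does not simply return to compound 1, as its 2-methylphenyl is not the group of compound 1, and only a partial reversal is expected. For compound 4 a step of a 3.1-fold lower number from compound 3 to compound 4 (0.49 log units; beyond the scatter) in this assay is expected, downward and beyond the scatter. The estimate for compound 4 is 15000 nM, with a range from 5000 nM to 45000 nM.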

Compound 4, half-maximal inhibitory concentration: 88400 nM
The estimate for compound 4 lay 5.9-fold (0.77 log units) below the measured number; measured number above the stated range.
By their numbers in this assay, from the lowest: compound 1; then compounds 3, 2 and 4 (each within the scatter of the next).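

Among these compounds, exchanging 4-methylphenyl for 2-methylphenyl on the carbonyl carbon gives a 12-fold higher number from compound 1 to compound 4 (1.07 log units; beyond the scatter) in this assay and shows that the low number of compound 1 does not follow from a methylphenyl group as such: the two isomeric groups differ beyond the scatter, a contrast the earlier compounds could not show. The other two steps, a 1.9-fold higher number from compound 3 to compound 4 (0.28 log units; within the scatter) and a 1.1-fold higher number from compound 2 to compound 4 (0.06 log units; within the scatter) are both within the scatter, so compounds 2, 3 and 4 form one group without an order, and at this position only compound 1 stands apart as the strongest of the four. Nothing on hand explains why these groups on the carbonyl carbon differ in this way.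

On these data alone, whether the low number is particular to 4-methylphenyl stays open, as 4-ethylphenyl, 4-methoxyphenyl or 4-aminophenyl on the same carbonyl carbon would test how narrow that requirement is. Also open, as far as these compounds go, is whether the separation of compound 1 from the other three reaches beyond this assay to other cell lines.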